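Swapping the Ring on the Amine Nitrogen in Compound 4

This account rests on a few compounds, and the source may have more. Where it says the series, first, only, none or still open, it means among the compounds named here.

Of the compounds shown here, three sharing one core have been tested in a functional assay on BGC-823 cells (Homo sapiens) for antiproliferative activity, read by MTT assay, with a stated time of 48 h; on this read-out higher numbers stand for weaker inhibition and lower numbers for stronger inhibition. Compound 1 `Fc1ccccc1N1CCN(Cn2nc(-c3ccc4c(c3)OCCO4)oc2=S)CC1` returns only a limit of the assay, > 50000 nM. Compound 2 `COc1cccc(N2CCN(Cn3nc(-c4ccc5c(c4)OCCO5)oc3=S)CC2)c1` likewise returns only a limit, > 50000 nM. Compound 3 `S=c1oc(-c2ccc3c(c2)OCCO3)nn1CN1CCN(c2ccccn2)CC1` is the only one of the three to yield a number, 25900 nM, so it stands as the sole readable point in this assay. The step of an at least 1.9-fold lower number from compound 1 to compound 3 (0.28 log units; that floor lies within the scatter) and the step of an at least 1.9-fold lower number from compound 2 to compound 3 (0.28 log units; that floor lies within the scatter) each rest on a limit at one end, as the limit of > 50000 nM in this assay, at which 2 of the 3 values shown sit, shows, and neither floor reaches beyond the scatter. The step that the two limits leave unreadable from compound 1 to compound 2 cannot be read at all.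

Compound 4 `S=c1oc(-c2ccc3c(c2)OCCO3)nn1CN1CCN(c2ccccc2)CC1` differs from compound 3 in one place: phenyl in place of pyridin-2-yl on an amine nitrogen in a ring. For the measured compounds named here, the steps that bear on this change come from the two compounds that carry a six-membered aromatic ring of carbon only on the same nitrogen, and both of those sit at the limit. Compound 4 is expected to give about 40000 nM, between 15000 nM and 100000 nM, an expected step of a 1.5-fold higher number from compound 3 to compound 4 (0.19 log units; within the scatter). That expectation rests on compounds 1 and 2, whose values both sit at the limit described by the limit of > 50000 nM in this assay, at which 2 of the 3 values shown sit.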

Compound 4, half-maximal inhibitory concentration: > 50000 nM
Compound 4 ended at the assay's limit; the forecaster's own chance of this, stated with the estimate: 45%; middle value at least 1.2-fold (0.09 log units) away from the limit.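

Compound 4 returns only a limit of the assay. In this assay, for the compounds shown here, the exchange of pyridin-2-yl for phenyl on the amine nitrogen gives an at least 1.9-fold higher number from compound 3 to compound 4 (0.28 log units; that floor lies within the scatter), the first comparison in which these two rings are the only difference, although this floor alone does not separate the two compounds. Removing fluoro or methoxy from the aromatic ring does not bring a readable value, the steps among compounds 1, 2 and 4 cannot be read, and compound 3 remains the only compound shown that carries pyridin-2-yl and the only one with a number: the limit of > 50000 nM in this assay, at which 3 of the 4 values shown sit.

Going by these compounds, how far compound 4 truly lies from compound 3 stays open. Also open, on these data alone, is whether pyridin-4-yl or pyrimidin-2-yl on the same nitrogen, or an amine on the phenyl ring, would give a number in this assay.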